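Swapping a bromo for trifluoromethyl on the aryl ring

The source may hold more compounds than are shown below. What is called first, only, known or untested is meant among the compounds shown, and "the series" means these compounds.

Measured compounds:
compound 1, `OC[C@H]1O[C@@H](n2cnc3c(NCc4ccc(Br)cc4)ncnc32)[C@H](O)[C@@H]1O`, 68200 nM
compound 2, `OC[C@H]1O[C@@H](n2cnc3c(NCc4ccc(Cl)c(Cl)c4)ncnc32)[C@H](O)[C@@H]1O`, 10800 nM
compound 3, `OC[C@H]1O[C@@H](n2cnc3c(NCc4ccc(F)c(Cl)c4)ncnc32)[C@H](O)[C@@H]1O`, 5500 nM

The three compounds share one core and differ only in the halogen pattern on the phenyl ring at the end of the side chain. In a functional assay on K562 cells (Homo sapiens) for antiproliferative activity, with a stated time of 72 h (on this read-out higher numbers stand for weaker inhibition and lower numbers for stronger inhibition), compound 1 gives 68200 nM, the highest of the three numbers, so it is the weakest inhibitor seen so far. Moving to the 3,4-dichlorophenyl analogue gives a 6.3-fold lower number from compound 1 to compound 2 (0.80 log units; beyond the scatter), and to the 3-chloro-4-fluorophenyl analogue gives a 12-fold lower number from compound 1 to compound 3 (1.09 log units; beyond the scatter); between those two, a 2.0-fold lower number from compound 2 to compound 3 (0.29 log units; within the scatter).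

Compound 4, `OC[C@H]1O[C@@H](n2cnc3c(NCc4ccc(C(F)(F)F)cc4)ncnc32)[C@H](O)[C@@H]1O`, has not yet been measured. Relative to compound 1 the difference is trifluoromethyl in place of bromo on an aromatic carbon. Among the compounds with values here, both measured steps from compound 1 add a second substituent rather than exchanging the single group already present, so neither bears directly on this change; the one single-atom swap, from compound 2 to compound 3, stayed within the scatter. Within the data shown here, no measured step therefore speaks for a clear gain or loss here, and only a small step, if any, is expected in this assay.

Compound 4 is accordingly estimated at 45000 nM, with a likely range from 15000 nM to 130000 nM, which would mean a 1.5-fold lower number from compound 1 to compound 4 (0.18 log units; within the scatter).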

Compound 4, half-maximal inhibitory concentration: > 166000 nM
Compound 4 gave a limit, no number; the forecaster's own chance of this, stated with the estimate: 10%; middle value at least 3.6-fold (0.56 log units) away from the limit.
By their numbers in this assay, from the lowest: compounds 3 and 2 (each within the scatter of the next); then compound 1. At a limit, above all of these: compound 4.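

Compound 4 gives only a limit, not a number: the limit of > 166000 nM in this assay, at which 1 of the 4 values shown sits. Within the data shown here, exchanging the single group on an aromatic carbon para to a large group is therefore not a neutral swap here: trifluoromethyl in place of bromo gives an at least 2.4-fold higher number from compound 1 to compound 4 (0.38 log units; beyond the scatter), the first measured exchange of that lone group, and it goes towards weaker inhibition, whereas the steps from compound 1 seen earlier went towards stronger inhibition. The gap to the two compounds with a halogen pair on the ring is larger, at an at least 15-fold higher number from compound 2 to compound 4 (1.18 log units; beyond the scatter) and an at least 30-fold higher number from compound 3 to compound 4 (1.47 log units; beyond the scatter), and each of these three steps gives only the smallest size the step can have, with its true size unreadable.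

On these data alone, how far compound 4 really lies from the others stays unknown, and so does whether a second halogen on its ring would lower its number, as the halogen pairs of compound 2 and compound 3 sit lower than compound 1. Also open, as far as these compounds go, is how a lone chloro, fluoro, methyl, methoxy or nitrile at this same place would compare with bromo and trifluoromethyl.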